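The source may report more compounds than this note shows. Statements on the series, on what has been measured and on what is new or still open speak of the compounds shown alone.

Measured so far:
- compound 1 `CON=C1CCC(N(c2cc(C#CC(C)(C)C)sc2C(=O)O)C(=O)[C@H]2CC[C@H](C)CC2)CC1`: > 20000 nM in an ADME assay on MT4 cells (Homo sapiens) for cytotoxicity, with a stated time of 5 days; a lower number here means that less compound is tolerated, a higher number that more compound is tolerated
- compound 2 `C[C@H]1CC[C@H](C(=O)N(c2cc(C#CC3(C(F)(F)F)CCC3)sc2C(=O)O)[C@H]2CC[C@H](Oc3ccc(=O)[nH]n3)CC2)CC1`: > 20000 nM in this assay

Compound 1 stands at the ceiling of this assay, with > 20000 nM reported as a limit rather than a number. Compound 2 also reaches only a limit, at > 20000 nM in this assay. Among the measured compounds shown here, the two values therefore show no difference between the compounds; both simply tolerate the highest concentration tested, which is what the one piece of evidence says (the limit of > 20000 nM in this assay, at which 2 of the 2 values shown sit).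

The step from compound 1 to compound 3 `CC(C)(C)C#Cc1cc(N(C(=O)[C@H]2CC[C@H](C)CC2)[C@H]2CC[C@H](OC3COC3)CC2)c(C(=O)O)s1` is a change on the amide-type nitrogen: a group of 11 heavy atoms (9 carbon, 2 oxygen; one four-membered non-aromatic ring with 1 hetero atom, one six-membered non-aromatic ring of carbon only) in place of a group of 9 heavy atoms (7 carbon, 1 nitrogen, 1 oxygen; one six-membered non-aromatic ring of carbon only), on an amide-type nitrogen

For the measured compounds named here, no measured step exists that would show how such an exchange moves the numbers in this assay. With both measured compounds sitting at the limit, the most reasonable expectation is that compound 3 behaves the same way, with a step from compound 1 to compound 3 of about a step that the limit leaves unreadable from compound 1 to compound 3, which is no change beyond the scatter, and most likely another limit rather than a number.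

Compound 3 is expected to give about 25000 nM in this assay, somewhere between 12000 nM and 60000 nM.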

Compound 3, half-maximal cytotoxic concentration: > 20000 nM
Compound 3: only a limit was reported; the forecaster's own chance of this, stated with the estimate: 85%; the middle value is on the limit's open side.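

In this assay compound 3 gives > 20000 nM, which is a limit and not a number. Compound 1 also stands at a limit, so no step can be read between compound 1 and compound 3: the limit of > 20000 nM in this assay, at which 3 of the 3 values shown sit.

The compounds shown leave open whether the 4-((oxetan-3-yl)oxy)cyclohexyl group changes the concentration tolerated at all.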